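Amino for methoxy on a second biphenyl core

A few compounds are considered here, and "the series" means these few. Any claim that something is new, unique, unknown or untested is made for them only; others in the source may bear on it.

Compound 1 `COc1ccccc1-c1ccccc1O` and compound 2 `Nc1ccccc1-c1ccccc1O` share one core, and compound 3 `COc1cccc(-c2ccc(O)cc2)c1` and the not yet measured compound 4 `Nc1cccc(-c2ccc(O)cc2)c1` share another; the difference between the two cores is not broken down here. All are judged in a functional assay on MCF7 cells (Homo sapiens) for cytotoxicity, read by MTT assay, with a stated time of 3 days; on this read-out higher numbers stand for weaker inhibition and lower numbers for stronger inhibition. Compound 1 gives > 100 ug/mL, which is a limit of the assay and not a number. Compound 2 gives 56 ug/mL, and compound 3 gives 41 ug/mL; these two values lie within the usual scatter of each other.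

The change from compound 1 to compound 2 is amino in place of methoxy on an aromatic carbon. It brings an at least 1.7-fold lower number from compound 1 to compound 2 (0.25 log units; that floor lies within the scatter); the step has only a floor because the limit of > 100 ug/mL in this assay, at which 1 of the 3 values shown sits, is all that compound 1 reports.

Compound 4 is reached by the same kind of change, (amino in place of methoxy on an aromatic carbon), but here the amino sits meta to the group of 7 heavy atoms rather than ortho to it. A reading of the step is therefore expected, not assured. Resting on the at least modest lowering seen in an at least 1.7-fold lower number from compound 1 to compound 2 (0.25 log units; that floor lies within the scatter) and on the starting value of compound 3, 41 ug/mL, the step from compound 3 to compound 4 is expected to be a 1.4-fold lower number from compound 3 to compound 4 (0.14 log units; within the scatter). Compound 4 is accordingly estimated at 30 ug/mL, with a likely span from 12 ug/mL to 80 ug/mL.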

Compound 4, half-maximal inhibitory concentration: 6.5 ug/mL
Estimate against measurement, compound 4: 4.6-fold (0.66 log units) above, and the stated range ends above it.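

In this assay, amino in place of methoxy brings a 6.3-fold lower number from compound 3 to compound 4 (0.80 log units; beyond the scatter), so on the core of compound 3 the change goes clearly beyond the usual scatter of repeated measurements. Set beside the same change on the core of compound 1, this step points the same way, but it cannot show that the size of the change carries over from one core to the other: the same change on two cores in this assay, an at least 1.7-fold lower number (0.25 log units; that floor lies within the scatter) from compound 1 to compound 2 and a 6.3-fold lower number (0.80 log units; beyond the scatter) from compound 3 to compound 4; the limit leaves it open whether they differ

The first of these steps starts from compound 1, which gives > 100 ug/mL, a limit of the assay and not a number, so the series shows two cores with a lower number after the swap and no general rule for other cores.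

The compounds shown leave open what other groups would do at the same place on the core of compound 3, such as an ethoxy group, a dimethylamino group or a carboxylic acid, and whether any of them would match amino. They also leave open how amino in place of methoxy behaves on a third core, and whether the step seen here holds in any cell line other than this one.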